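This account rests on a few compounds, and the source may have more. Where it says the series, first, only, none or still open, it means among the compounds named here.

Of the compounds shown here, three have so far been measured in a functional assay on MCF7 cells (Homo sapiens), read by MTT assay, with a stated time of 48 h; a lower number here means a stronger inhibitor, a higher number a weaker inhibitor. Compound 1 `CCN(CC)CCNC(=O)c1ccc(C(CC)(CC)c2ccc(OCC(=O)C(C)(C)C)c(C)c2)n1CC` gives 690 nM. Compound 2 `CCN(CC)CCNC(=O)c1ccc(C(CC)(CC)c2ccc(OCC(O)C(C)(C)C)c(C)c2)n1CC` gives 690 nM, and compound 3 `CCn1c(C(=O)NCCCN(C)C)ccc1C(CC)(CC)c1ccc(OCC(O)C(C)(C)C)c(C)c1` gives 490 nM. Compound 2 stands level with compound 1, and compound 3 lies within the scatter of both, so the three numbers cannot be ordered. The step of no change at the digits printed from compound 1 to compound 2 (within the scatter) and the step of a 1.4-fold lower number from compound 2 to compound 3 (0.15 log units; within the scatter) are both small.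

Compound 4 `CCn1c(C(=O)Oc2ccc(CCO)cc2)ccc1C(CC)(CC)c1ccc(OCC(O)C(C)(C)C)c(C)c1` has not yet been measured. It differs from compound 2 by a group of 10 heavy atoms (8 carbon, 2 oxygen; one six-membered aromatic ring of carbon only) in place of a group of 8 heavy atoms (6 carbon, 2 nitrogen; no ring), on a carbonyl carbon. Neither measured step bears directly on this change. The step of a 1.4-fold lower number from compound 2 to compound 3 (0.15 log units; within the scatter) touched the same side of the core, but it kept the amide-type nitrogen and only altered the amine at the chain end, whereas here the whole (2-(diethylamino)ethyl)amino group leaves and a ring-bearing group without nitrogen enters. The change is therefore larger than any seen so far, and the record gives no guide to its direction. A modest loss of inhibition is taken as the most likely outcome, held with wide uncertainty. Compound 4 is expected to give 1500 nM, with a range from 350 nM to 6500 nM. This estimate corresponds to an expected step of a 2.2-fold higher number from compound 2 to compound 4 (0.34 log units; beyond the scatter).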

Compound 4, half-maximal inhibitory concentration: > 50000 nM
Compound 4: only a limit was reported; the forecaster's own chance of this, stated with the estimate: 12%; middle value at least 33-fold (1.52 log units) from the limit.
By their numbers in this assay, from the lowest: compounds 3, 1 and 2 (each within the scatter of the next). At a limit, above all of these: compound 4.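

Compound 4 is recorded in this assay only as a limit: the limit of > 50000 nM in this assay, at which 1 of the 4 values shown sits.

Among these compounds, this is the first large step, since the group on the carbonyl carbon whose other neighbour is an aromatic carbon was replaced whole, and it reads as an at least 72-fold higher number from compound 2 to compound 4 (1.86 log units; beyond the scatter) and as an at least 100-fold higher number from compound 3 to compound 4 (2.00 log units; beyond the scatter). The earlier changes, at the ketone carbon in no change at the digits printed from compound 1 to compound 2 (within the scatter) and at the chain end of the amine in a 1.4-fold lower number from compound 2 to compound 3 (0.15 log units; within the scatter), stayed within the scatter, so they gave no sign that this position could matter so much. Compound 4 shows that the number is sensitive to what sits on this carbonyl carbon, at least when the amide-type nitrogen and the terminal amine leave together and an oxygen-linked aromatic ring enters.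

The change combines these replacements in one step, so the compounds shown cannot say which of them accounts for the loss. An ester that keeps a diethylamino chain, or an amide that carries the same hydroxyethyl-bearing benzene ring, would separate the terminal amine from the linking atom, and neither is among the compounds shown.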